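The compounds below may be only part of what the source reports. "The series", "measured", "known", "first", "only" and "open" are said of these compounds alone.

Measured so far in an assay on HEK293 cells for displacement of a labelled ligand from Neuronal acetylcholine receptor; alpha3/beta4 (Homo sapiens), read by scintillation counting, with a stated time of 120 min; on this read-out higher numbers stand for weaker inhibition and lower numbers for stronger inhibition:
- compound 1, `c1ccc(COc2cccc(-c3cn([C@@H]4CN5CCC4CC5)nn3)c2)cc1`: 6.67 nM
- compound 2, `FCCOc1cccc(-c2cn([C@H]3CN4CCC3CC4)nn2)c1`: 558 nM
- compound 3, `Oc1ccc(-c2cn([C@@H]3CN4CCC3CC4)nn2)cc1`: 2.48 nM

Compound 2 stands at the highest number of the three, the weakest binding shown. Its nearest neighbour is compound 1, whose number is far lower, and compound 3 lies further still; both gaps are well beyond the scatter. For the measured compounds named here, no pair of the measured compounds differs in a single place, so none of these gaps can be read as a clean step.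

Compound 4, `c1ccc(COc2cccc(-c3cn([C@H]4CN5CCC4CC5)nn3)c2)cc1`, is the next compound in line. Its change from compound 2 is phenyl in place of fluoromethyl on a saturated chain carbon bound to an oxygen on an aromatic ring. The same benzyloxy group is carried by compound 1, although compound 1 and compound 4 are written with opposite configuration at the saturated ring carbon, while compound 2 and compound 4 share it. The benzyloxy compound 1 gives the far lower number of the two, so a large drop from compound 2 is the expected direction, with the stereochemical difference leaving room for doubt on its size.

The step from compound 2 to compound 4 is expected to be a 28-fold lower number from compound 2 to compound 4 (1.45 log units; beyond the scatter), clearly beyond the scatter. Compound 4 is expected to give roughly 20 nM, within 4 nM to 120 nM.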

Compound 4, inhibition constant: 631 nM
Beside the measured number, compound 4's estimate is 32-fold (1.50 log units) below it; the measured number lies above the stated range.
By their numbers in this assay, from the lowest: compound 3; then compound 1; then compounds 2 and 4 (each within the scatter of the next).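

In this assay, for the compounds shown here, the same atoms and bonds give very different numbers, a 95-fold higher number from compound 1 to compound 4 (1.98 log units; beyond the scatter), and the only place of difference is a stereocentre at a saturated ring carbon, drawn S in compound 1 and R in compound 4; this is the first single-place step to show that this stereocentre can matter on its own. With that stereocentre written the same way in both compounds, phenyl in place of fluoromethyl on a saturated chain carbon bound to an oxygen on an aromatic ring leaves the number within the scatter, a 1.1-fold higher number from compound 2 to compound 4 (0.05 log units; within the scatter), so at this configuration the exchange of 2-fluoroethoxy for benzyloxy shows no measurable consequence in this assay. The record offers one point on the large gap between the two stereo forms: the fact that one of compounds 1 and 4 is drawn with a defined configuration and the other without, at the place where they differ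

The compounds shown leave open whether the same indifference to the 2-fluoroethoxy to benzyloxy exchange holds with the stereocentre drawn S, as no S partner of compound 2 is among them, and compound 3 differs from the others in more than one place. Also open, going by these compounds, is whether an amine or a carboxylic acid at the end of that chain, or a longer chain, would stay within the scatter at this position.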